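The compounds below may be only part of what the source reports. "The series", "measured", "known", "first", "only" and "open" are said of these compounds alone.

Compound 1 `CONC(=O)[C@@H]1CC=C(CCC=C(C)C)C[C@H]1c1ccccc1` gives 2700 nM in an assay on isolated protein for inhibition of Apoptosis regulator Bcl-2 (Homo sapiens), read by fluorescence polarization, with stated times of 5 min and 10 min; on this read-out higher numbers stand for weaker inhibition and lower numbers for stronger inhibition. Compound 2 `COC(=O)CCNC(=O)[C@H]1CC=C(CCC=C(C)C)C[C@@H]1c1ccccc1` gives 3100 nM in the same assay. Compound 3 `CC(C)=CCCC1=CC[C@H](C(=O)N(C)C)[C@@H](c2ccccc2)C1` reaches only the limit > 23000 nM, a limit of the assay rather than a number.

Compound 1 holds the lowest of the two numbers shown, with compound 2 sitting within the usual scatter of it. The unmeasured compound 4 `CON(C)C(=O)[C@@H]1CC=C(CCC=C(C)C)C[C@H]1c1ccccc1` differs from compound 1 by methyl in place of hydrogen on an amide-type nitrogen. Going by the values given here, the one measured step that touches substitution on the amide-type nitrogen is an at least 7.4-fold higher number from compound 2 to compound 3 (0.87 log units; beyond the scatter), where the result sits at the limit of > 23000 nM in this assay, at which 1 of the 3 values shown sits. On that basis a weakening step is expected in this assay for compound 4, with the expected step being a 2.2-fold higher number from compound 1 to compound 4 (0.35 log units; beyond the scatter). Compound 4 is therefore estimated at 6000 nM, in the range 2500 nM to 20000 nM.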

Compound 4, inhibition constant: > 23000 nM
Compound 4: only a limit was reported; the forecaster's own chance of this, stated with the estimate: 15%; at least 3.8-fold (0.58 log units) between middle value and limit.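

In this assay, methyl in place of hydrogen on the amide-type nitrogen costs a clear loss on its own, with an at least 8.5-fold higher number from compound 1 to compound 4 (0.93 log units; beyond the scatter). Compounds 1 and 2, which keep the amide hydrogen, give numbers, whereas compounds 3 and 4, which lack it, do not, and this pair isolates that single change. Compound 4 stands at a limit, not a number, so the full size of the step stays unknown: the limit of > 23000 nM in this assay, at which 2 of the 4 values shown sit.

The compounds shown leave open whether an ethyl group on this nitrogen would fare the same. They also leave open whether a carboxylic acid on the chain of compound 2 would keep a measurable number.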